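Piperidine thiosemicarbazone: methyl on the pyridine ring

The source may report more compounds than this note shows. Statements on the series, on what has been measured and on what is new or still open speak of the compounds shown alone.

Measured compounds:
compound 1 `Cc1ccnc(/C(N)=N/NC(=S)N2CCOCC2)c1` — 82.7%
compound 2 `Cc1ccnc(/C(N)=N/NC(=S)N2CCSCC2)c1` — 91.6%
compound 3 `N/C(=N\NC(=S)N1CCCCC1)c1ccccn1` — 86%

All three were tested in a functional assay on HeLa cells (Homo sapiens) for cytotoxicity, read by MTT assay, with a stated time of 72 h, tested at 100 uM; a higher number here means more inhibition of growth at the concentration tested, a lower number less inhibition of growth. Compound 1 and compound 2 both carry a methyl on their ring, and the step from one to the other concerns only the group on the thiocarbonyl carbon: a number 8.9 percentage points higher from compound 1 to compound 2 (within the scatter). Compound 3 lacks that methyl and carries a piperidin-1-yl instead of the morpholine or thiomorpholine. On the numbers shown, compound 3 sits close to both of the others: its gap to compound 1 and its gap to compound 2 each stay within the usual scatter, so no ranking among the three can be read from these values.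

Compound 4 `Cc1ccnc(/C(N)=N/NC(=S)N2CCCCC2)c1` differs from compound 3 in one place: methyl in place of hydrogen on an aromatic carbon. Among the measured compounds shown here, no measured step covers exactly this change; the only step available, between compound 1 and compound 2, is a different change and stayed within the scatter. Compound 1 and compound 2, which already carry the methyl, give values close to compound 3, so the change is expected to move this assay by a number 1 percentage points higher from compound 3 to compound 4 (within the scatter) at most. For compound 4 the estimate is 87%, with a range of 74% to 96%.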

Compound 4, percent growth inhibition at one concentration: 70.8%
Compound 4: middle estimate off by 16.2 percentage points, on the high side, outside the stated range (below it).
By their numbers in this assay, from the lowest: compound 4; then compounds 1, 3 and 2 (each within the scatter of the next).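

In this assay, methyl in place of hydrogen on an aromatic carbon, opposite the ring nitrogen, gives a number 15.2 percentage points lower from compound 3 to compound 4 (beyond the scatter) with piperidin-1-yl held constant, so this small change at this position can alter growth inhibition by more than the usual scatter. With the methyl held constant, piperidin-1-yl in place of thiomorpholin-4-yl gives a number 20.8 percentage points lower from compound 2 to compound 4 (beyond the scatter) and piperidin-1-yl in place of morpholin-4-yl gives a number 11.9 percentage points lower from compound 1 to compound 4 (beyond the scatter) on the thiocarbonyl carbon, whereas the exchange of morpholin-4-yl for thiomorpholin-4-yl had stayed within the scatter. The group on the thiocarbonyl carbon therefore also matters once the methyl is present, and the values of the methyl compounds carrying other groups there did not reveal the effect of adding the methyl to the piperidin-1-yl compound.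

On these data alone, it remains open whether the methyl would have a similar effect alongside morpholin-4-yl or thiomorpholin-4-yl, and whether an ethyl or a methoxy group at the same place would behave like the methyl. Nothing measured here gives a reason for any of these steps.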